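The source may report more compounds than this note shows. Statements on the series, on what has been measured and on what is new or still open speak of the compounds shown alone.

Within the data shown here, the three compounds measured so far share one core and differ only in the group carried on one aromatic nitrogen. Compound 1 `CCNCCn1c(N2CCN(C)CC2)nc2ccccc21` gives 290 nM in a functional assay on ileum for inhibition of histamine H1 receptor (Cavia porcellus); a lower number here means a stronger inhibitor, a higher number a weaker inhibitor. Compound 2 `CCCOCCn1c(N2CCN(C)CC2)nc2ccccc21` gives 20 nM in this assay. Compound 3 `CN1CCN(c2nc3ccccc3n2-c2ccccc2)CC1` gives 760 nM in this assay, the highest of the three numbers and so the weakest inhibitor among them. Compound 4 `CC(C)CCn1c(N2CCN(C)CC2)nc2ccccc21` has not been measured yet; it differs from compound 3 by isopentyl in place of phenyl on an aromatic nitrogen. Among the measured compounds shown here, two measured steps bear on this change, both of which place a phenyl on that nitrogen instead of a chain: a 38-fold higher number from compound 2 to compound 3 (1.58 log units; beyond the scatter) and a 2.6-fold higher number from compound 1 to compound 3 (0.42 log units; beyond the scatter). Going from compound 3 to compound 4 reverses that direction, exchanging the phenyl for a chain, though one without the oxygen of compound 2 or the nitrogen of compound 1. A lower number is therefore expected, of a size between those two steps: an 11-fold lower number from compound 3 to compound 4 (1.04 log units; beyond the scatter). Compound 4 is thus estimated to give 70 nM in this assay, with a range from 15 nM to 300 nM.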

Compound 4, half-maximal inhibitory concentration: 1400 nM
Compound 4: middle estimate off by 20-fold (1.30 log units), on the low side; measured number above the stated range.
By their numbers in this assay, from the lowest: compound 2; then compound 1; then compounds 3 and 4 (each within the scatter of the next).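

Swapping phenyl for isopentyl on this aromatic nitrogen leaves the number within the usual scatter (a 1.8-fold higher number from compound 3 to compound 4 (0.27 log units; within the scatter)), so a chain there does not by itself give a stronger inhibitor than a phenyl. What the chain carries matters more: isopropyl in place of propoxy gives a large rise (a 70-fold higher number from compound 2 to compound 4 (1.85 log units; beyond the scatter)), and isopropyl in place of ethylamino gives a modest one (a 4.8-fold higher number from compound 1 to compound 4 (0.68 log units; beyond the scatter)), so both chains holding an oxygen or a nitrogen beat the all-carbon isopentyl, and no compound shown goes against this. No measurement here explains why these chains differ.

The compounds shown leave open whether a shorter ether such as 2-methoxyethyl, or an alcohol such as 2-hydroxyethyl, would keep the low number of compound 2. They also leave open how a longer all-carbon chain such as hexyl would compare with isopentyl.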